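The compounds below may be only part of what the source reports. "The series", "measured", "known", "first", "only" and "open" are said of these compounds alone.

Among the compounds with values here, compound 1 `CNc1cc(=O)n(Cc2cc(C)cc(C)c2)c(=O)n1Cc1ccccc1` is one of the two measured members. In an ADME assay on MT4 cells (Homo sapiens) for cytotoxicity, read by MTT assay, with a stated time of 4 days (on this read-out lower numbers stand for higher toxicity in this test and higher numbers for lower toxicity in this test), compound 1 gives 65000 nM. Compound 2 `Cc1cc(C)cc(Cn2c(=O)cc(N)n(Cc3ccncc3)c2=O)c1`, the other measured member, is reported in this assay only as a limit, > 100000 nM. Compound 1 therefore holds the only number shown, the remaining value sitting at the limit of > 100000 nM in this assay, at which 1 of the 2 values shown sits. Compound 3 `Cc1cc(C)cc(Cn2c(=O)cc(NC3CC3)n(Cc3ccccc3)c2=O)c1` has yet to be measured in this assay; it differs from compound 1 by cyclopropyl in place of methyl on a nitrogen on an aromatic ring. No step between measured compounds is shown, and for compound 3 no shift beyond the usual scatter is expected, so the step of a 1.1-fold lower number from compound 1 to compound 3 (0.03 log units; within the scatter) is estimated to be small. Compound 3 is expected to give about 60000 nM, within 25000 nM to 150000 nM.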

Compound 3, half-maximal cytotoxic concentration: > 100000 nM
Compound 3: no number, only a limit (the forecaster's own chance of this, stated with the estimate: 30%); middle value at least 1.6-fold (0.22 log units) away from the limit.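

In this assay, cyclopropyl in place of methyl on a nitrogen on an aromatic ring gives an at least 1.5-fold higher number from compound 1 to compound 3 (0.18 log units; that floor lies within the scatter). On these data alone, compound 3 is reported only as a limit, so the true size of the step remains unknown and this change shows no sign of higher toxicity in this test. At this read-out, more values now sit at a limit than are given as numbers: the limit of > 100000 nM in this assay, at which 2 of the 3 values shown sit.

As far as these compounds go, it remains open how far compound 3 actually lies from compound 1. Also open, from the compounds shown here alone, is how a longer chain such as butylamino or a dimethylamino group would read at this position.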